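This account rests on a few compounds, and the source may have more. Where it says the series, first, only, none or still open, it means among the compounds named here.

Of the compounds shown here, three built on one shared core have been tested in a functional assay on isolated protein for inhibition of Glucose-dependent insulinotropic receptor (Homo sapiens), read by HTRF and cAMP accumulation; a lower number here means that less compound is needed, a higher number that more compound is needed for the effect. Compound 1 `Cc1nc(S(C)(=O)=O)ccc1Oc1ncnc(OC2CCN(C(=O)OC(C)C)CC2)c1F` gives 21 nM. Compound 2 `Cc1nc(S(C)(=O)=O)ccc1Oc1ncnc(OC2CCN(C(=O)O[C@H](C)C(F)(F)F)CC2)c1F` gives 9.2 nM, and compound 3 `Cc1nc(S(C)(=O)=O)ccc1Oc1ncnc(OC2CCN(C(=O)O[C@@H](C)C(F)(F)F)CC2)c1F` gives 9.86 nM. Compound 3 thus stands second highest of the three, within the scatter of compound 2 and beyond the scatter only against compound 1. The change a 2.3-fold lower number from compound 1 to compound 2 (0.36 log units; beyond the scatter) and the matching change a 2.1-fold lower number from compound 1 to compound 3 (0.33 log units; beyond the scatter) were both modest, while the near-identical numbers of compounds 2 and 3 fit (the fact that compounds 2 and 3 differ only in the configuration as drawn). Compound 4 `Cc1nc(S(C)(=O)=O)ccc1Oc1ncnc(OC2CCN(C(=O)SC(C)C)CC2)c1F` differs from compound 3 in that (isopropylsulfanyl in place of 1-(trifluoromethyl)ethoxy on a carbonyl carbon). Since replacing isopropyl with 1-(trifluoromethyl)ethyl lowered the number modestly, a return to an isopropyl-bearing group is expected to raise it again, estimated as a 2.0-fold higher number from compound 3 to compound 4 (0.31 log units; beyond the scatter) in this assay. Compound 4 is therefore estimated at 20 nM, with a range from 7 nM to 60 nM.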

Compound 4, half-maximal effective concentration: 6.8 nM
Beside the measured number, compound 4's estimate is 2.9-fold (0.47 log units) above it, and the stated range ends above it.
By their numbers in this assay, from the lowest: compounds 4, 2 and 3 (each within the scatter of the next); then compound 1.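

At this carbonyl carbon, isopropylsulfanyl cannot be told apart from either 1-(trifluoromethyl)ethoxy form: a 1.5-fold lower number from compound 3 to compound 4 (0.16 log units; within the scatter) and a 1.4-fold lower number from compound 2 to compound 4 (0.13 log units; within the scatter). Keeping the isopropyl and swapping only the oxygen for sulfur gives a 3.1-fold lower number from compound 1 to compound 4 (0.49 log units; beyond the scatter), so an isopropyl here does not by itself go with the higher number. No fact at hand accounts for this sulfur swap. Still open, going by these compounds, is whether 1-(trifluoromethyl)ethylsulfanyl, which joins the two changes, would lower the number further. Also open, on these data alone, is how an amine or a longer chain on this carbonyl carbon would compare.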